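Ortho-chloro step on two anilide cores, growth inhibition

This account rests on a few compounds, and the source may have more. Where it says the series, first, only, none or still open, it means among the compounds named here.

Compound 1 `O=C(CCCCC(S)CCS)Nc1ccccc1` and compound 2 `O=C(CCCCC(S)CCS)Nc1ccccc1Cl` share one core; compound 3 `CC(=O)SCCC(CCCCC(=O)Nc1ccccc1)SC(C)=O` carries a second core, and compound 4 `CC(=O)SCCC(CCCCC(=O)Nc1ccccc1Cl)SC(C)=O` is built on it but has not yet been measured. The difference between the two cores is not broken down here.

In a functional assay on HO8910 cells (Homo sapiens) for inhibition, read by MTT assay, with a stated time of 24 h, tested at 0.1 ug/mL (a higher number here means more inhibition of growth at the concentration tested, a lower number less inhibition of growth), compound 1 gives 7.37%. Compound 2 gives 6.11% in this assay. The change from compound 1 to compound 2 is chloro in place of hydrogen on an aromatic carbon, and the step it made, a number 1.3 percentage points lower from compound 1 to compound 2 (within the scatter), lies within the scatter. Compound 3 gives 8.33% in this assay; its value and that of compound 1 are within the scatter of each other, as are its value and that of compound 2.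

The change from compound 3 to compound 4 is chloro in place of hydrogen on an aromatic carbon, the same change as from compound 1 to compound 2, and it occurs twice among the four compounds. Among the compounds with values here, with only one measured instance, the expectation for compound 4 rests on that single step: because a number 1.3 percentage points lower from compound 1 to compound 2 (within the scatter) stayed within the scatter, the step from compound 3 to compound 4 is expected to be of the same small size, a number 1.3 percentage points lower from compound 3 to compound 4 (within the scatter). The estimate for compound 4 in this assay is therefore 7%, expected to fall between -2% and 16%.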

Compound 4, percent growth inhibition at one concentration: 2.48%
Estimate against measurement, compound 4: 4.5 percentage points above; the range from low to high includes it.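

In this assay, the change from phenyl to 2-chlorophenyl gives a number 5.9 percentage points lower from compound 3 to compound 4 (within the scatter), so on this core, as on the core of compound 1, the step stays inside the usual variation. Set side by side, the two steps cannot be told apart, and the data give no sign that the core alters the effect of the change: the same change on two cores in this assay, a number 1.3 percentage points lower (within the scatter) from compound 1 to compound 2 and a number 5.9 percentage points lower (within the scatter) from compound 3 to compound 4, 4.6 percentage points apart, within the scatter of two such steps. This supports carrying the change from one core to the other only in a limited sense, since the two steps rest on two pairs of compounds at a single concentration and neither step can be told from the scatter, so the data do not show that the chloro group has any effect on either core or that the true size of the step is the same on both.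

The compounds shown leave open whether a different group on the same aromatic carbon, such as an amine, a methoxy group or a carboxylic acid, would give a step beyond the scatter. They also leave open what a longer chain on the amide carbonyl would do, and whether the chloro step would remain this small at a concentration giving greater inhibition of growth.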